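A few compounds are considered here, and "the series" means these few. Any claim that something is new, unique, unknown or untested is made for them only; others in the source may bear on it.

Measured compounds and their values in an ADME assay on NIH3T3 cells (Mus musculus) for cytotoxicity, read by MTT assay, with a stated time of 24 h; a lower number here means a stronger inhibitor, a higher number a weaker inhibitor:

Compound 1 `Cn1nnnc1SCC(=O)N/N=c1/scc(-c2ccc(F)cc2)n1-c1ccccc1` — 113 ug/mL
Compound 2 `Cn1nnnc1SCC(=O)N/N=c1/scc(-c2ccc(Br)cc2)n1-c1ccccc1` — 19.3 ug/mL
Compound 3 `COc1ccc(-c2cs/c(=N/NC(=O)CSc3nnnn3C)n2-c2ccccc2)cc1` — 45 ug/mL

Compound 3 holds the second highest of the three numbers in this assay. Its nearest neighbour is compound 2: a 2.3-fold higher number from compound 2 to compound 3 (0.37 log units; beyond the scatter). Its furthest is compound 1: a 2.5-fold lower number from compound 1 to compound 3 (0.40 log units; beyond the scatter). The largest step in the set runs between those two: a 5.9-fold lower number from compound 1 to compound 2 (0.77 log units; beyond the scatter). So exchanging the group on the four-position of the pendant phenyl ring has moved the number by modest amounts in both directions across the series.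

Compound 4 `Cn1nnnc1SCC(=O)N/N=c1/scc(-c2ccc([N+](=O)[O-])cc2)n1-c1ccccc1` differs from compound 3 in one place: nitro in place of methoxy on an aromatic carbon. The same difference, cut one bond further out, reads 4-methoxyphenyl to 4-nitrophenyl.

Among the measured compounds shown here, no measured step involves a nitro group, so the three steps bear on the new compound only in showing how far a change at this carbon has shifted the number so far. On that basis a step in this assay no larger than those already seen is expected, with no clear direction. The estimate for compound 4 is 35 ug/mL, expected within the range 12 ug/mL to 110 ug/mL, which corresponds to an expected step of a 1.3-fold lower number from compound 3 to compound 4 (0.11 log units; within the scatter).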

Compound 4, half-maximal inhibitory concentration: 167 ug/mL
Estimate against measurement, compound 4: 4.8-fold (0.68 log units) below; the whole stated range lies below it.
By their numbers in this assay, from the lowest: compound 2; then compound 3; then compounds 1 and 4 (each within the scatter of the next).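

In this assay the change from 4-methoxyphenyl to 4-nitrophenyl gives the clearest upward move from methoxy so far (a 3.7-fold higher number from compound 3 to compound 4 (0.57 log units; beyond the scatter)), and the step from bromo (an 8.7-fold higher number from compound 2 to compound 4 (0.94 log units; beyond the scatter)) is the widest yet seen at this aromatic carbon, which shows that the span at this one place is larger than the first three compounds indicated. Nitro and fluoro cannot be told apart (a 1.5-fold higher number from compound 1 to compound 4 (0.17 log units; within the scatter)), so the four groups fall into three levels: bromo alone at the lowest number, methoxy in the middle, and nitro and fluoro together at the high end. Nothing measured in the series accounts for this order, or for nitro and fluoro sitting together.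

On these data alone, what the number does with other groups at this carbon remains open: an amine, a carboxylic acid or a chloro group could fall anywhere in this span or outside it. Also open, as far as these compounds go, is whether the same order of bromo, methoxy, and nitro with fluoro would hold at another carbon of that ring, or with a change elsewhere in the shared core.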